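A few compounds are considered here, and "the series" means these few. Any claim that something is new, unique, unknown or untested is made for them only; others in the source may bear on it.

Of the compounds shown here, three built on one shared core have been measured in a functional assay on CHO cells for agonist activity at Free fatty acid receptor 1 (Homo sapiens), read by FLIPR and calcium flux; a higher number here means that more compound is needed for the effect, a lower number that less compound is needed. Compound 2 `O=C(O)COc1ccc(NCc2cccc(-c3ccccc3)c2)cc1F` gives 58.5 nM. Compound 3 `O=C(O)COc1ccc(NCc2ccc(Cl)c(-c3ccccc3)c2)cc1F` gives 51.7 nM, and compound 1 `CCOc1cc(C)c(-c2cccc(CNc3ccc(OCC(=O)O)c(F)c3)c2)c(C)c1` gives 24.2 nM. Compound 2 thus has the highest of the three numbers: compound 3 stands nearest to it, and the step of a 1.1-fold lower number from compound 2 to compound 3 (0.05 log units; within the scatter) stays within the scatter, whereas compound 1 stands furthest away, with a gap that goes beyond the scatter.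

Compound 4 `CC(C)c1ccccc1-c1cccc(CNc2ccc(OCC(=O)O)c(F)c2)c1` has not yet been measured. It differs from compound 2 in one place: isopropyl in place of hydrogen on an aromatic carbon. Cut one bond further out, the change reads phenyl to 2-isopropylphenyl, with the new group placed ortho to a large group. Among the measured compounds shown here, only one measured step changes a single position, the step from compound 2 to compound 3, and it concerns a different ring and showed no movement. For the measured compounds named here, the only compound with groups on the ring that here gains the isopropyl is compound 1, which gives 24.2 nM, while compound 2 gives 58.5 nM.

On that basis the step of a 2.0-fold lower number from compound 2 to compound 4 (0.29 log units; within the scatter) is expected to be modest and toward a lower number. Compound 4 is estimated at 30 nM, with a likely range from 12 nM to 75 nM.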

Compound 4, half-maximal effective concentration: 86.2 nM
Compound 4: middle estimate off by 2.9-fold (0.46 log units), on the low side; measured number above the stated range.
By their numbers in this assay, from the lowest: compound 1; then compounds 3, 2 and 4 (each within the scatter of the next).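

In this assay, the step of a 1.5-fold higher number from compound 2 to compound 4 (0.17 log units; within the scatter) stays inside the scatter, so the two numbers cannot be told apart. This is the first single change shown on the ring that gains the isopropyl, as the earlier single step concerned a different ring; it shows that a branched group of 3 carbons, with no hydrogen-bond donors or acceptors and no net charge, can stand on this aromatic carbon, ortho to a large group, without the number leaving the scatter of compound 2. No measurement at hand explains this result.

The ring that carries the isopropyl here also carries several groups in compound 1, which gives 24.2 nM, and the compounds shown do not reveal what any one of those groups does on its own. As far as these compounds go, it also remains open whether a hydroxyl group or an amine on the same aromatic carbon, in place of the isopropyl, would keep the number within the scatter of compound 2 or move it clearly away.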